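Nitro in Place of Hydroxy: What the Flat Steps Suggest

The source may report more compounds than this note shows. Statements on the series, on what has been measured and on what is new or still open speak of the compounds shown alone.

Measured so far:
compound 1 `O=C(N/N=C\c1ccccc1)Nc1nnc(COc2ccc3ccccc3c2)o1`: 300 mg/kg
compound 2 `O=C(N/N=C(/c1ccccc1)c1ccc(O)cc1)Nc1nnc(COc2ccc3ccccc3c2)o1`: 300 mg/kg
compound 3 `C/C(=N/NC(=O)Nc1nnc(COc2ccc3ccccc3c2)o1)c1ccc(O)cc1`: 300 mg/kg

In a functional assay on the whole organism (strain Swiss albino) with Mus musculus as the target, in the maximal electroshock model, with a stated time of 4 h (a lower number here means that less compound is needed, a higher number that more compound is needed for the effect), compound 3 gives 300 mg/kg, level with compound 1 and compound 2. The two steps that reach it, no change at the digits printed from compound 1 to compound 3 (within the scatter) and no change at the digits printed from compound 2 to compound 3 (within the scatter), both stayed flat, so changes at the carbon with a double bond to nitrogen and at the amide-type nitrogen left this read-out untouched.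

Compound 4 `C/C(=N/NC(=O)Nc1nnc(COc2ccc3ccccc3c2)o1)c1ccc([N+](=O)[O-])cc1` differs from compound 3 by nitro in place of hydroxy on an aromatic carbon. Within the data shown here, no measured step touches this position, and the steps that do exist were flat, so no change beyond the scatter is expected: the step of no change at the digits printed from compound 3 to compound 4 (within the scatter) is estimated to stay small. Compound 4 is therefore expected to give 300 mg/kg, with a range from 100 mg/kg to 600 mg/kg.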

Compound 4, minimum effective dose: 300 mg/kg
Beside the measured number, compound 4's estimate shows no gap at the digits printed, and the stated range covers the measured number.
By their numbers in this assay, from the lowest: compounds 1, 2, 3 and 4 (each within the scatter of the next).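

Swapping 4-hydroxyphenyl for 4-nitrophenyl gives the first step that touches this aromatic carbon, and in this assay it reads no change at the digits printed from compound 3 to compound 4 (within the scatter). The change removes the hydrogen-bond donor of hydroxy and adds a larger group with no donor, yet the minimum effective dose does not respond. Nothing measured here explains this flat result.

As far as these compounds go, whether an amine or a carboxylic acid at this place would behave the same remains open. So does whether any change to the shared core would move the dose.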